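This account rests on a few compounds, and the source may have more. Where it says the series, first, only, none or still open, it means among the compounds named here.

Of the compounds shown here, two of a shared core have been tested for their effect on liver-derived cells. In an ADME assay on L02 cells (Homo sapiens) for cytotoxicity, read by MTT assay, with a stated time of 24 h (on this read-out lower numbers stand for higher toxicity in this test and higher numbers for lower toxicity in this test), compound 1 `O=c1[nH]cc(S(=O)(=O)Nc2ccccc2-c2cn(-c3ccccc3)nn2)c(=O)[nH]1` gives 10600 nM. Among the compounds with values here, compound 2 `Cc1ccc(-n2cc(-c3cccc(NS(=O)(=O)c4c[nH]c(=O)[nH]c4=O)c3)nn2)cc1`, which carries a 4-methylphenyl on an aromatic nitrogen and has its sulfonamide linked to a different position of the central ring, gives 23100 nM in this assay, the higher of the two numbers, with compound 1 lying beyond the scatter below it; the two structures differ in more than one place, so their values show only that compound 2 is the less toxic of the pair in this test.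

Compound 3 `O=c1[nH]cc(S(=O)(=O)Nc2cccc(-c3cn(-c4ccccc4Cl)nn3)c2)c(=O)[nH]1` is not yet measured. It differs from compound 2 by 2-chlorophenyl in place of 4-methylphenyl on an aromatic nitrogen, in words: 2-chlorophenyl in place of 4-methylphenyl on an aromatic nitrogen. Within the data shown here, no measured pair shows a comparable change, so its effect in this assay is unknown. Since the part of the molecule that changes is small and the rest is kept, a step no larger than the usual scatter, in either direction, is expected, which is the meaning of a 1.3-fold lower number from compound 2 to compound 3 (0.11 log units; within the scatter). Compound 3 is therefore estimated at 18000 nM in this assay, with a range from 7000 nM to 45000 nM.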

Compound 3, half-maximal cytotoxic concentration: 11500 nM
Compound 3: the middle estimate sits 1.6-fold (0.19 log units) above what was measured, within the range that was stated.
By their numbers in this assay, from the lowest: compounds 1, 3 and 2 (each within the scatter of the next, the first and the last beyond it).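

Within the data shown here, the pair of compound 2 and compound 3 is the first here to differ in one place only, so it gives the first direct reading of the group on the aromatic nitrogen of the five-membered ring. In this assay, 2-chlorophenyl in place of 4-methylphenyl gives a 2.0-fold lower number from compound 2 to compound 3 (0.30 log units; within the scatter), so this exchange does not separate the two compounds in this test, even though the chlorine sits on a different ring position from the methyl. Nothing measured here bears on why the two values stand so close.

Among these compounds, the pair covers only two substituted phenyl groups, both with the same heavy-atom count and no hydrogen-bond donors or acceptors, so it remains open whether a phenyl carrying an amine or a carboxylic acid, or a longer chain in place of the ring, would shift the number beyond the scatter. Among the compounds shown here, the effect of the chlorine or the methyl against a plain phenyl on this core also stays open, since compound 1, the only compound with a plain phenyl, differs from both others in more than one place.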